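The compounds below may be only part of what the source reports. "The series", "measured", "known", "first", "only" and "open" are said of these compounds alone.

Compound 1 `NS(=O)(=O)c1ccc(N2N=C(c3ccc(Oc4ccccc4)cc3)CC2c2cccc(F)c2)cc1`: 28000 nM
Compound 2 `Cc1cccc(C2CC(c3ccc(OCc4ccccc4)cc3)=NN2c2ccc(S(N)(=O)=O)cc2)c1`: 100000 nM

Both compounds were tested in an ADME assay on Vero 76 cells (Chlorocebus sabaeus) for cytotoxicity, read by MTT assay, with a stated time of 96 h; on this read-out lower numbers stand for higher toxicity in this test and higher numbers for lower toxicity in this test. Compound 1 stands lowest of the two numbers at 28000 nM. Compound 2 reads 100000 nM, a gap beyond the scatter, so compound 1 is the more toxic of the pair in this test. Going by the values given here, these two compounds do not form a step in one place, so the data hold no measured step to show what a single change does here.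

The next compound to be measured is compound 3 `NS(=O)(=O)c1ccc(N2N=C(c3ccc(Oc4ccccc4)cc3)CC2c2ccccc2F)cc1`. It keeps the core of compound 1 and carries 2-fluorophenyl in place of 3-fluorophenyl on a saturated ring carbon. The two compounds have the same atoms, joined differently, and the counts of the groups that leave and enter are the same. Among the compounds with values here, with no measured step as a guide, no step beyond the scatter is expected in this assay, and the expectation stays anchored on compound 1 at 28000 nM. The expected change is a 1.1-fold higher number from compound 1 to compound 3 (0.03 log units; within the scatter). For compound 3 the estimated value is 30000 nM, with an expected range of 13000 nM to 75000 nM.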

Compound 3, half-maximal cytotoxic concentration: 96000 nM
Compound 3: the middle estimate sits 3.2-fold (0.51 log units) below what was measured, and the stated range ends below it.
By their numbers in this assay, from the lowest: compound 1; then compounds 3 and 2 (each within the scatter of the next).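

In this assay, putting 2-fluorophenyl in place of 3-fluorophenyl on the saturated ring carbon gives a 3.4-fold higher number from compound 1 to compound 3 (0.54 log units; beyond the scatter). This shows that the read-out at this position depends on where the fluorine stands on the phenyl ring, even though the group that leaves and the group that enters have the same atoms and the same counts. Going by these compounds alone, it is the first step measured in one place, however, and it rests on this single pair, so no wider pattern can be drawn from it. Nothing available explains why these two fluorophenyl groups differ in this test.

The compounds shown leave open whether a chlorine or a methoxy group in place of the fluorine, or an unsubstituted phenyl on the same saturated ring carbon, would read nearer to compound 1 or to compound 3. They also leave open whether the same fluorine shift would give a step of like size if a benzyloxy group replaced the phenoxy group on the other phenyl ring.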